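This account rests on a few compounds, and the source may have more. Where it says the series, first, only, none or still open, it means among the compounds named here.

Measured so far:
- compound 1, `CC/C=C/[C@H](CC)C[C@@]1(C)C[C@@H](CC)[C@@H](CC(=O)OC)OO1` — > 1000 nM in a functional assay on Microglia cells (Rattus norvegicus); on this read-out higher numbers stand for weaker inhibition and lower numbers for stronger inhibition
- compound 2, `CC/C=C/[C@H](CC)C[C@]1(CC)C=C(CC)/C(=C/C(=O)OC)O1` — > 10000 nM in this assay

Compound 2 stands at a limit of this assay and not at a number: its value in this assay is > 10000 nM, which is the limit described as the limit of > 10000 nM in this assay, at which 1 of the 2 values shown sits. Compound 1 also stands at a limit and not at a number, the one described as the limit of > 1000 nM in this assay, at which 1 of the 2 values shown sits. For the measured compounds named here, no single-point step connects compound 1 and compound 2; their two values show only that both fall outside the measured range, at different limits. Nothing further is said of the pair.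

The step now followed leads from compound 2 to compound 3, `CC/C=C/[C@H](CC)C[C@]1(C)C=C(CC)/C(=C/C(=O)OC)O1`, not yet measured in this assay. The structural change is hydrogen in place of methyl on a saturated chain carbon bound to a saturated ring carbon. The change is small, one carbon at a saturated chain position; with compound 2 already at a limit, no step beyond the usual scatter is expected in either direction. Compound 3 is expected to remain at or around the limit, with a step that the limit leaves unreadable from compound 2 to compound 3 as the estimated step. For compound 3 the estimate in this assay is 20000 nM, in the range 5000 nM to 80000 nM, most likely reported again only as a limit.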

Compound 3, half-maximal inhibitory concentration: > 10000 nM
Compound 3 gave a limit, no number; the forecaster's own chance of this, stated with the estimate: 85%; the middle value is on the limit's open side.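

No step can be read between compound 2 and compound 3 in this assay: each stands at a limit of the assay and not at a number. The compounds shown leave open whether hydrogen in place of methyl on a saturated chain carbon bound to a saturated ring carbon changes inhibition at all.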